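This account rests on a few compounds, and the source may have more. Where it says the series, first, only, none or still open, it means among the compounds named here.

Measured so far in a functional assay on BT-474 cells (Homo sapiens) for inhibition, read by fluorescence, with a stated time of 72 h; a higher number here means a weaker inhibitor of growth, a lower number a stronger inhibitor of growth:
- compound 1 `CC(C)CCn1cnc2c(Nc3ccc(Cl)cc3)nc(N[C@H]3CC[C@H](N)CC3)nc21` gives 5100 nM
- compound 2 `CCCCCCn1cnc2c(Nc3ccc(Cl)cc3)nc(N[C@H]3CC[C@H](N)CC3)nc21` gives 5500 nM
- compound 3 `CCCCn1cnc2c(NCc3cccc(Cl)c3)nc(N[C@H]3CC[C@H](N)CC3)nc21` gives 4700 nM

All three compounds sit in one band, and compound 1 lies within the scatter of both others. Compound 4 `CC(C)CCn1cnc2c(Nc3cccc(Cl)c3)nc(N[C@H]3CC[C@H](N)CC3)nc21` is the next case. Its difference from compound 1 is 3-chlorophenyl in place of 4-chlorophenyl on a nitrogen on an aromatic ring.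

For the measured compounds named here, no measured step covers this change directly. Going by the values given here, the only step available is a 1.1-fold higher number from compound 1 to compound 2 (0.03 log units; within the scatter), and it concerns the saturated chain, not the chlorophenyl group. Compound 3 also carries a 3-chlorophenyl group, but with a different link and a different chain, so it is only a loose guide. Even so, compound 3 at 4700 nM stays in the same band.

On these data alone, no step beyond the scatter is therefore expected in this assay, though the range must stay wide because the change itself is untested. The estimated step is a 1.0-fold lower number from compound 1 to compound 4 (0.01 log units; within the scatter). For compound 4 the expected value is 5000 nM, with an estimated range from 2000 nM to 10000 nM.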

Compound 4, concentration for 50% growth inhibition: 3800 nM
Compound 4: middle estimate off by 1.3-fold (0.12 log units), on the high side, and the stated range covers the measured number.
By their numbers in this assay, from the lowest: compounds 4, 3, 1 and 2 (each within the scatter of the next).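

On the nitrogen on an aromatic ring, 3-chlorophenyl in place of 4-chlorophenyl gives in this assay a 1.3-fold lower number from compound 1 to compound 4 (0.13 log units; within the scatter) and so leaves the two chlorophenyl isomers unresolved. For the compounds shown here, this is the first direct reading of the change with everything else in compound 1 held fixed, and it replaces the loose guide from compound 3, which differs in more than one place. The compounds shown offer nothing that bears on a reason for this result.

Still open, on these data alone, is whether a different group on that nitrogen, such as unsubstituted phenyl, a pyridine ring or a benzyl group on the compound 1 chain, would give a step beyond the scatter. The only chain step shown, a 1.1-fold higher number from compound 1 to compound 2 (0.03 log units; within the scatter), leaves open whether a shorter chain or a chain ending in an amine or a carboxylic acid would do so.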